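The compounds below may be only part of what the source reports. "The series", "measured", "known", "first", "only" and "open" are said of these compounds alone.

The shared core carries a double-bonded chain ending in a carbonyl carbon, and the group on that carbon is what varies. Compound 1 `O=C(O)[C@@H]1CCCN1C(=O)/C=C/c1ccncc1-c1ccc2ccccc2c1` has 2-carboxypyrrolidin-1-yl there; in a functional assay on HCT-116 cells (Homo sapiens) for inhibition, read by MTT assay, with a stated time of 72 h (a higher number here means a weaker inhibitor of growth, a lower number a stronger inhibitor of growth), compound 1 gives "not determined" (no result reported), so it stands nowhere on the numbers. Compound 3 `Cn1ccc2cc(-c3cnccc3/C=C/C(=O)N3CCOCC3)ccc21` likewise gives "not determined" (no result reported) in this assay. Within the data shown here, the one measured member is compound 2 `CCOC(=O)/C=C/c1ccncc1-c1ccc2cc[nH]c2c1`, and in this assay compound 2 gives 2140 nM. Compound 1 thus offers no anchor of its own, and the only reference point for the series is the value of compound 2.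

Compound 4 `CN(C)C(=O)/C=C/c1ccncc1-c1ccc2ccccc2c1` differs from compound 1 in a single place: dimethylamino in place of 2-carboxypyrrolidin-1-yl on a carbonyl carbon. Among the measured compounds shown here, no step between two measured compounds exists here, so the size of this change in this assay cannot be read off; in this assay the step from compound 1 to compound 4 is expected to be of modest size, not clearly in either direction, and quite possibly within the usual scatter. On that basis, and leaning on the value of compound 2, compound 4 is estimated to give 3000 nM in this assay, with a range from 800 nM to 12000 nM.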

Compound 4, concentration for 50% growth inhibition: 4540 nM
Compound 4: middle estimate off by 1.5-fold (0.18 log units), on the low side; low and high end bracket the measured number.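

Among these compounds, compound 1 has no single number in this assay, so the result for compound 4 gives no step that can be read between the two. The compounds shown leave open how far exchanging 2-carboxypyrrolidin-1-yl for dimethylamino on a carbonyl carbon shifts growth inhibition in this assay. Nothing available here offers an explanation of the value of compound 4.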